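This account rests on a few compounds, and the source may have more. Where it says the series, first, only, none or still open, it means among the compounds named here.

Measured in an assay on CHO cells for displacement of a labelled ligand from adenosine receptor A3 (Homo sapiens), read by scintillation counting, tested at 10 uM; a higher number here means more inhibition at the concentration tested (going by the name of the read-out), a lower number less inhibition:
compound 1 `CC(C)(C)Cc1c(-c2ccncc2)sc(N)c1C(=O)c1ccc(Cl)cc1` — 6%
compound 2 `CC(C)(C)Cc1c(-c2cccc(F)c2F)sc(N)c1C(=O)c1ccc(Cl)cc1` — 1%
compound 3 `CC(C)(C)Cc1c(-c2cc(F)ccc2F)sc(N)c1C(=O)c1ccc(Cl)cc1` — 1%

Compound 3 gives the same reading as compound 2, and the remaining step is a number 5 percentage points lower from compound 1 to compound 3 (within the scatter), so all three numbers lie within the usual spread of this assay. Compound 4 `CC(C)(C)Cc1c(-c2c(F)cccc2F)sc(N)c1C(=O)c1ccc(Cl)cc1` differs from compound 3 only in how the same atoms are joined: 2,6-difluorophenyl in place of 2,5-difluorophenyl on an aromatic carbon. Among the compounds with values here, the closest precedent is the step between the two measured difluorophenyl compounds, no change at the digits printed from compound 2 to compound 3 (within the scatter), and the steps from the pyridin-4-yl compound, a number 5 percentage points lower from compound 1 to compound 2 (within the scatter) and a number 5 percentage points lower from compound 1 to compound 3 (within the scatter), were likewise small. A step of a number 1 percentage points higher from compound 3 to compound 4 (within the scatter) is therefore expected, nothing beyond the scatter. For compound 4 the estimate in this assay is 2%, between 0% and 10%.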

Compound 4, a percentage reported as inhibition, at one concentration (the size of the read-out at that concentration, not a potency): 1%
Compound 4: middle estimate off by 1 percentage points, on the high side; the measured number falls inside the stated range.
By their numbers in this assay, from the lowest: compounds 2, 3, 4 and 1 (each within the scatter of the next).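

In this assay, the third difluorophenyl pattern at this position, on the aromatic carbon next to the ring sulfur, adds no difference: no change at the digits printed from compound 3 to compound 4 (within the scatter), and no change at the digits printed from compound 2 to compound 4 (within the scatter). Measured against the pyridin-4-yl compound, the 2,6-difluorophenyl group also gives only a small step, a number 5 percentage points lower from compound 1 to compound 4 (within the scatter). Nothing available here offers an explanation for these readings.

On these data alone, whether any group here can move the reading beyond the scatter remains open. A phenyl ring bearing a carboxylic acid or a primary amine, for example, could be informative.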